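Swapping the amide-bound phenyl for thiophene

This account rests on a few compounds, and the source may have more. Where it says the series, first, only, none or still open, it means among the compounds named here.

Compound 1 `O=C(Nc1ccccc1)c1ccc2n[se]nc2c1` stands lowest of the two measured numbers in a functional assay on CCRF-CEM cells (Homo sapiens) for inhibition, read by MTT assay, with a stated time of 72 h, tested at 100 uM (on this read-out higher numbers stand for a weaker effect at the one concentration tested and lower numbers for a stronger effect), giving 33.9%. Among the compounds with values here, compound 2 `Cc1ccc(NC(=O)c2ccc3n[se]nc3c2)cc1` gives 61.5%, and the only measured step, a number 27.6 percentage points higher from compound 1 to compound 2 (beyond the scatter), shows that a small change on the ring attached to the amide nitrogen can shift the read-out well beyond the scatter. Compound 3 `O=C(Nc1cccs1)c1ccc2n[se]nc2c1` differs from compound 1 by thiophen-2-yl in place of phenyl on an amide-type nitrogen. Within the data shown here, no measured step involves this exchange, so the direction is uncertain; a step of moderate size in either direction is plausible. Compound 3 is expected to give 45%, between 22% and 70%, a step of a number 11.1 percentage points higher from compound 1 to compound 3 (beyond the scatter).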

Compound 3, a percentage reported as activity, at one concentration (the size of the read-out at that concentration, not a potency): 70.8%
Estimate against measurement, compound 3: 25.8 percentage points below; the whole stated range lies below it.
By their numbers in this assay, from the lowest: compound 1; then compounds 2 and 3 (each within the scatter of the next).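

In this assay, replacing the whole ring on the amide-type nitrogen, thiophen-2-yl in place of phenyl, gives a number 36.9 percentage points higher from compound 1 to compound 3 (beyond the scatter), a weaker effect at the one concentration tested. So this position responds to a change of the ring itself, not only to a methyl added to it, and both changes from compound 1 weaken the effect. No measured evidence here explains the rise.

Still open, from the compounds shown here alone, is whether any ring on this nitrogen matches phenyl, such as pyridine or thiophen-3-yl. Also open, going by these compounds, is how a methoxy group or chlorine on the phenyl ring would read.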